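A few compounds are considered here, and "the series" means these few. Any claim that something is new, unique, unknown or untested is made for them only; others in the source may bear on it.

Compound 3 (`CN(C)C(=O)CCC(=O)c1cccc(C(F)(F)F)c1`) is known in a functional assay on the whole organism with Mus musculus as the target (a higher number here means that more compound is needed for the effect, a lower number that less compound is needed), only as > 50 mg/kg, which is a limit and not a number. Compound 4 (`CC(C)NC(=O)CCC(=O)c1cccc(C(F)(F)F)c1`) shares its core and has isopropylamino in place of dimethylamino on a carbonyl carbon, whose other neighbour is a saturated chain carbon: isopropylamino in place of dimethylamino on a carbonyl carbon. Cut one bond further out, the same difference reads dimethylcarbamoyl to isopropylcarbamoyl.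

The nearest measured comparison comes from a different core. In this assay, compound 1 (`NC(=O)/C=C/c1cccc(C(F)(F)F)c1`) gives 37.5 mg/kg, and compound 2 (`CCC(O)CNC(=O)/C=C/c1cccc(C(F)(F)F)c1`) gives 87.5 mg/kg. There, 2-hydroxybutyl replaces hydrogen on an amide-type nitrogen, and the result is a 2.3-fold higher number from compound 1 to compound 2 (0.37 log units; beyond the scatter). Among the measured compounds shown here, this is the only measured step on such a nitrogen, and it is modest. It also involves a different substituent and starts from a hydrogen rather than a dimethylamino group, so it offers only weak guidance.

On the strength of that step, a modest rise in the number is expected in this assay, or no change beyond the scatter, and no large step in either direction. The estimated step is a step that the limit leaves unreadable from compound 3 to compound 4. The expected value for compound 4 is 60 mg/kg, with an estimated range of 25 mg/kg to 130 mg/kg.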

Compound 4, dose for half-maximal effect: > 200 mg/kg
Compound 4: a limit, no number; the forecaster's own chance of this, stated with the estimate: 45%; middle value at least 3.3-fold (0.52 log units) from the limit.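

In this assay compound 3 is a limit, > 50 mg/kg. Compound 4 is also a limit, > 200 mg/kg. Among the compounds shown here, no step between compound 3 and compound 4 can be read from these two limits. The compounds shown leave open the direction and size of any change in this assay with isopropylamino in place of dimethylamino on a carbonyl carbon.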